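This account rests on a few compounds, and the source may have more. Where it says the series, first, only, none or still open, it means among the compounds named here.

Measured so far:
compound 1: `CCCCNc1nc(N)nc(C)c1CCc1ccccc1`, 1190 nM
compound 2: `CCCCNc1nc(N)nc(C)c1CCCN(C)C`, 126 nM

Going by the values given here, in an assay on HEK293 cells for agonist activity at Toll-like receptor 8 (Homo sapiens), read by spectrophotometry (a higher number here means that more compound is needed for the effect, a lower number that less compound is needed), compound 2 has the lowest of the two numbers; the only step available, a 9.4-fold lower number from compound 1 to compound 2 (0.98 log units; beyond the scatter), lies beyond the scatter. Compound 3 `CCCCNc1nc(N)nc(C)c1CCCc1ccccc1` differs from compound 2 by phenyl in place of dimethylamino on a saturated chain carbon, three bonds along the chain from an aromatic carbon. This largely undoes that earlier step, except that the ring now sits three bonds along the chain rather than two, as in compound 1. A rise back toward the number of compound 1 is therefore expected. Compound 3 is expected to give 700 nM, with a range of 250 nM to 2000 nM, a step of a 5.6-fold higher number from compound 2 to compound 3 (0.74 log units; beyond the scatter).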

Compound 3, half-maximal effective concentration: 749 nM
For compound 3 the middle estimate is 1.1-fold (0.03 log units) below the measured one; low and high end bracket the measured number.
By their numbers in this assay, from the lowest: compound 2; then compounds 3 and 1 (each within the scatter of the next).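

Compound 2 keeps its edge over a phenyl-ended chain of the same length, so the gap seen against compound 1 does not depend on the shorter chain alone: in this assay the change gives a 5.9-fold higher number from compound 2 to compound 3 (0.77 log units; beyond the scatter) for this swap. Benzyl in place of phenyl, which adds one chain carbon, gives a 1.6-fold lower number from compound 1 to compound 3 (0.20 log units; within the scatter) and so separates nothing. Nothing available here explains why dimethylamino and phenyl differ. Still open, as far as these compounds go, is whether another amine, such as a pyrrolidine or a primary amine, would match dimethylamino, and how a longer chain ending in dimethylamino would behave.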